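Compound 1 to compound 3: amino in place of nitro

The compounds below may be only part of what the source reports. "The series", "measured", "known", "first", "only" and "open" are said of these compounds alone.

Compound 1 (`COc1ccc(C2=C(c3cc(OC)c(OC)c(OC)c3)CC(O)C2=O)cc1[N+](=O)[O-]`) is the reference for this step. In an ADME assay on ECV-304 cells (Homo sapiens) for cytotoxicity, read by MTT assay, with a stated time of 72 h (on this read-out higher numbers stand for weaker inhibition and lower numbers for stronger inhibition), compound 1 gives > 100 ug/mL, which is a limit and not a number. Compound 2 (`COc1ccc(C2=C(c3cc(OC)c(OC)c(OC)c3)CC(O[SiH2]C(C)(C)C)C2=O)cc1[N+](=O)[O-]`) gives > 100 ug/mL in this assay, and this too is a limit. Among the measured compounds shown here, the series so far therefore stands at the limit of > 100 ug/mL in this assay, at which 2 of the 2 values shown sit.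

Compound 3 (`COc1ccc(C2=C(c3cc(OC)c(OC)c(OC)c3)CC(O)C2=O)cc1N`) carries amino in place of nitro on an aromatic carbon. For the measured compounds named here, the only measured step is a step that the two limits leave unreadable from compound 1 to compound 2. It lies at a different place in the structure and gives no size to carry over to the aromatic carbon. No measured step sizes this change, so the expectation is loose: compound 3 may stay at the same limit, or it may give a number on the side of stronger inhibition in this assay. For compound 3 the estimated step is an at least 2.0-fold lower number from compound 1 to compound 3 (0.30 log units; that floor lies within the scatter). Compound 3 is estimated at 50 ug/mL, with an expected range of 3 ug/mL to 150 ug/mL.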

Compound 3, half-maximal inhibitory concentration: > 100 ug/mL
Compound 3 was reported as a limit; the forecaster's own chance of this, stated with the estimate: 50%; middle value at least 2.0-fold (0.30 log units) away from the limit.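

Compound 3 gives > 100 ug/mL in this assay, which is a limit. Compound 1 also stands at a limit, so no step can be read between compound 1 and compound 3, and the series remains at: the limit of > 100 ug/mL in this assay, at which 3 of the 3 values shown sit.

The compounds shown leave open whether amino in place of nitro, or any other change shown, shifts this read-out at all.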